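Same ring swap on two related cores

The compounds below may be only part of what the source reports. "The series", "measured", "known", "first", "only" and "open" are said of these compounds alone.

Measured in a functional assay on HeLa cells (Homo sapiens) for inhibition, read by MTT assay, with a stated time of 72 h; on this read-out higher numbers stand for weaker inhibition and lower numbers for stronger inhibition:

compound 1 `Cc1noc(C)c1-c1cnc(N)c(Oc2ccc(C(=O)Nc3ccccc3Cl)cc2)n1` — 81300 nM
compound 2 `Cn1cc(-c2cnc(N)c(Oc3ccc(C(=O)Nc4ccccc4Cl)cc3)n2)cn1` — 73000 nM
compound 3 `Cc1noc(C)c1-c1cnc(N)c(Sc2ccc(C(=O)Nc3ccc(Cl)cc3)cc2)n1` — 38400 nM

Compound 2 differs from compound 1 by 1-methyl-1H-pyrazol-4-yl in place of 3,5-dimethyl-1,2-oxazol-4-yl on an aromatic carbon; in this assay that change produced a 1.1-fold lower number from compound 1 to compound 2 (0.05 log units; within the scatter), so the two are indistinguishable on this read-out. Compound 3 carries a different core from compound 1; how the two cores differ is not broken down here, and the two values are all that can be compared. Among the three, compound 3 gives the lowest number, but its step to compound 2 lies within the scatter.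

Compound 4 `Cn1cc(-c2cnc(N)c(Sc3ccc(C(=O)Nc4ccc(Cl)cc4)cc3)n2)cn1` is not yet measured. It stands to compound 3 as compound 2 stands to compound 1: the change is 1-methyl-1H-pyrazol-4-yl in place of 3,5-dimethyl-1,2-oxazol-4-yl on an aromatic carbon, at the same place as before. Within the data shown here, the only precedent is compound 1 to compound 2, where the step was a 1.1-fold lower number from compound 1 to compound 2 (0.05 log units; within the scatter). On that basis the step from compound 3 to compound 4 is expected to be small, a 1.1-fold lower number from compound 3 to compound 4 (0.04 log units; within the scatter), because a 1.1-fold lower number from compound 1 to compound 2 (0.05 log units; within the scatter) was small. Compound 4 is therefore estimated at 35000 nM, with a range of 15000 nM to 80000 nM.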

Compound 4, half-maximal inhibitory concentration: 42700 nM
Compound 4: middle estimate off by 1.2-fold (0.09 log units), on the low side, within the range that was stated.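

In this assay, replacing 3,5-dimethyl-1,2-oxazol-4-yl with 1-methyl-1H-pyrazol-4-yl gives a 1.1-fold higher number from compound 3 to compound 4 (0.05 log units; within the scatter), so the change has no readable effect on this core either. Set beside the earlier step, the change behaves alike on both cores, with no difference that can be read between them: the same change on two cores in this assay, a 1.1-fold lower number (0.05 log units; within the scatter) from compound 1 to compound 2 and a 1.1-fold higher number (0.05 log units; within the scatter) from compound 3 to compound 4, 1.2-fold (0.09 log units) apart, within the scatter of two such steps This supports carrying the swap between these two cores as a change with no readable effect on this read-out, but it rests on only two pairs, shows nothing about a third core and gives no reason why the two groups are interchangeable here.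

Open, going by these compounds, is whether a group of a different kind on this aromatic carbon, such as an amine or a carboxylic acid in place of 1-methyl-1H-pyrazol-4-yl, would shift the number beyond the scatter. Also open, on these data alone, is whether the two rings would remain interchangeable on a read-out other than this cell assay.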